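The compounds below may be only part of what the source reports. "The series", "measured", "known", "first", "only" and "open" are said of these compounds alone.

Measured so far:
compound 1, `COc1ccc(-c2cc(/C=C/C(=O)c3ccc(N)cc3)[nH]n2)cc1`, 100%
compound 2, `COc1cc(-c2cc(/C=C/C(=O)c3ccc(N)cc3)[nH]n2)cc(OC)c1OC`, 98%

In a functional assay on OVCAR-8 cells (Homo sapiens) for cytotoxicity, read by sulforhodamine B assay, with a stated time of 48 h, tested at 0.1 uM (on this read-out higher numbers stand for a weaker effect at the one concentration tested and lower numbers for a stronger effect), compound 1 gives 100% and compound 2 gives 98%; the two numbers lie within the scatter of each other, so no order between them is read. Compound 3, `COc1ccc(C(=O)/C=C/c2cc(-c3cc(OC)c(OC)c(OC)c3)n[nH]2)cc1`, is not yet measured. It differs from compound 2 by methoxy in place of amino on an aromatic carbon. Among the compounds with values here, no step between measured compounds is available to calibrate this change. With compound 2 at 98%, the expected step of a number 1 percentage points higher from compound 2 to compound 3 (within the scatter) is none beyond the scatter, in either direction. Compound 3 is estimated at 99%, in the range 88% to 108%.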

Compound 3, a percentage reported as activity, at one concentration (the size of the read-out at that concentration, not a potency): 98%
Estimate against measurement, compound 3: 1 percentage points above, and the stated range covers the measured number.
By their numbers in this assay, from the lowest: compounds 2, 3 and 1 (each within the scatter of the next).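

In this assay, methoxy in place of amino on the aromatic carbon para to a large group gives no change at the digits printed from compound 2 to compound 3 (within the scatter). Within the data shown here, this is the first single-place step, and at this one concentration the read-out does not separate the two groups at this position. Nothing at hand bears on why the step reads this way.

The read-out at a single concentration leaves open whether the two groups would separate at other concentrations. Also open, as far as these compounds go, is how a carboxylic acid or a dimethylamino group would read at this position.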